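A few compounds are considered here, and "the series" means these few. Any claim that something is new, unique, unknown or untested is made for them only; others in the source may bear on it.

The account concerns a small set of acids built on a shared core and varied at an amine nitrogen in a ring. Compound 1 `Cc1ccc(-c2c3c(nc(C)c2[C@H](OC(C)(C)C)C(=O)O)CCN(c2ccccc2)C3)cc1` was examined in an ADME assay on MT2 cells (Homo sapiens) for cytotoxicity, read by XTT assay, with a stated time of 4 days; a lower number here means that less compound is tolerated, a higher number that more compound is tolerated. In this assay compound 1 gives > 40000 nM, which is a limit of the assay and not a number. Two relatives of compound 1 are compound 2 `Cc1nc2c(c(-c3cc(F)c4c(c3C)CCCO4)c1[C@H](OC(C)(C)C)C(=O)O)CN(CC1CC1c1ccccc1)CC2` and compound 3 `Cc1nc2c(c(-c3cc(F)c4c(c3C)CCCO4)c1[C@H](OC(C)(C)C)C(=O)O)CN(CCCc1ccccc1F)CC2`. In this assay compound 2 gives > 40000 nM, again a limit. In this assay compound 3 gives > 40000 nM, also a limit. Within the data shown here, the only step between neighbours, a step that the two limits leave unreadable from compound 2 to compound 3, cannot be sized. Compound 1 thus stands at the limit, and so do the two values beside it: the limit of > 40000 nM in this assay, at which 3 of the 3 values shown sit.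

The unmeasured compound 4 `Cc1ccc(-c2c3c(nc(C)c2[C@H](OC(C)(C)C)C(=O)O)CCN(C(=O)CCc2ccccc2)C3)cc1` differs from compound 1 in one place: phenethylcarbonyl in place of phenyl on an amine nitrogen in a ring. Among the measured compounds shown here, no measured step bears on this change directly; the single step known, a step that the two limits leave unreadable from compound 2 to compound 3, concerns another position and is itself unreadable, so neither a size nor a direction can be taken from it. With every value of the set resting at the limit, compound 4 is expected to sit there as well, and the step that the limit leaves unreadable from compound 1 to compound 4 is expected to be no larger than the scatter. For compound 4 in this assay the estimate is 50000 nM, with a range from 20000 nM to 150000 nM.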

Compound 4, half-maximal cytotoxic concentration: > 40000 nM
Compound 4: no number, only a limit; the forecaster's own chance of this, stated with the estimate: 85%; the middle value is on the limit's open side.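

In this assay compound 4 gives > 40000 nM, a limit of the assay and not a number. Compound 1 also stands at a limit, so the change from phenyl to phenethylcarbonyl between compound 1 and compound 4 yields no readable step. The compounds shown leave open how far any of them lies from that limit: the limit of > 40000 nM in this assay, at which 4 of the 4 values shown sit.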